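Benzyl hydroxamic acid series: growth inhibition working notes

This account rests on a few compounds, and the source may have more. Where it says the series, first, only, none or still open, it means among the compounds named here.

Measured so far:
compound 1, `O=C(CCC1=CCN(Cc2ccc(F)cc2)C1=O)NO`: 6060 nM
compound 2, `O=C(CCC1=CCN(Cc2cccc(Br)c2)C1=O)NO`: 4280 nM

Both compounds were run in a functional assay on NUGC-3 cells (Homo sapiens) for inhibition, read by sulforhodamine B assay; a lower number here means a stronger inhibitor of growth, a higher number a weaker inhibitor of growth. Compound 1 gives 6060 nM and compound 2 gives 4280 nM; the two numbers lie within the usual scatter of each other, so neither stands apart and compound 1 is simply the first of two near-equal results.

Compound 3, `CC(C)(C)c1ccc(CN2CC=C(CCC(=O)NO)C2=O)cc1`, differs from compound 1 by tert-butyl in place of fluoro on an aromatic carbon. Going by the values given here, no measured pair shows this change, and the two measured compounds give no guide to its size. On that basis the step of a 1.3-fold lower number from compound 1 to compound 3 (0.13 log units; within the scatter) is expected to stay within the scatter. Compound 3 is therefore expected to give 4500 nM, with a range of 1500 nM to 13000 nM.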

Compound 3, concentration for 50% growth inhibition: 720 nM
Compound 3: the middle estimate sits 6.3-fold (0.80 log units) above what was measured, outside the stated range (below it).
By their numbers in this assay, from the lowest: compound 3; then compounds 2 and 1 (each within the scatter of the next).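

Tert-butyl in place of fluoro on the aromatic carbon gives an 8.4-fold lower number from compound 1 to compound 3 (0.93 log units; beyond the scatter) in this assay. Going by these compounds alone, this is the first step to lie beyond the scatter, and it shows that the number in this assay responds to the group carried at this position. No measurement on hand explains the step. From the compounds shown here alone, whether the lower number tracks the four carbons of tert-butyl or the loss of fluoro stays open. Also open, going by these compounds, is how a smaller alkyl such as methyl, or an amine, would behave at the same place.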